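Taking the benzyl group off compound 3

A few compounds are considered here, and "the series" means these few. Any claim that something is new, unique, unknown or untested is made for them only; others in the source may bear on it.

Compound 1 `CC(=O)OC[C@H]1O[C@@H](CC(=O)CC2(O)C(=O)N(Cc3ccc(F)cc3)c3ccccc32)[C@H](OC(C)=O)[C@@H](OC(C)=O)[C@@H]1OC(C)=O`, compound 2 `CC(=O)OC[C@H]1O[C@@H](CC(=O)CC2(O)C(=O)N(Cc3cccc(C)c3)c3ccc(Cl)cc32)[C@H](OC(C)=O)[C@@H](OC(C)=O)[C@@H]1OC(C)=O` and compound 3 `CC(=O)OC[C@H]1O[C@@H](CC(=O)/C=C2\C(=O)N(Cc3ccccc3)c3ccccc32)[C@H](OC(C)=O)[C@@H](OC(C)=O)[C@@H]1OC(C)=O` are close structural relatives, but only one of them has a usable number. In an ADME assay on Vero cells (Chlorocebus sabaeus) for cytotoxicity, read by resazurin assay, with a stated time of 72 h (a lower number here means that less compound is tolerated, a higher number that more compound is tolerated), compound 1 is recorded as "not determined" (no result reported). Compound 2 is recorded in the same way, as "not determined" (no result reported). Compound 3 gives 71200 nM, and with nothing to compare it against, this value can't yet be called high or low within the series.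

Compound 4 `CC(=O)OC[C@H]1O[C@@H](CC(=O)/C=C2\C(=O)Nc3ccccc32)[C@H](OC(C)=O)[C@@H](OC(C)=O)[C@@H]1OC(C)=O` is still waiting for its measurement. It differs from compound 3 by a single change: hydrogen in place of benzyl on an amide-type nitrogen in a ring, which is hydrogen in place of benzyl on an amide-type nitrogen in a ring.

Going by the values given here, no measured pair shows what this swap does in this assay, so any expectation is loose. A moderate move toward a higher number seems most likely, although a result within the scatter would be no surprise. The expected change is a 1.7-fold higher number from compound 3 to compound 4 (0.23 log units; within the scatter). For compound 4 the estimated value is 120000 nM, with an expected range from 45000 nM to 300000 nM.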

Compound 4, half-maximal cytotoxic concentration: 127000 nM
Beside the measured number, compound 4's estimate is 1.1-fold (0.02 log units) below it, and the stated range covers the measured number.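

In this assay, putting hydrogen in place of benzyl on the amide-type nitrogen in a ring gives a 1.8-fold higher number from compound 3 to compound 4 (0.25 log units; within the scatter). This first readable step at this position shows that the whole benzyl group, aromatic ring included, can go without the result leaving the normal spread of repeat measurements, so this one pair gives no sign that the group matters for how much compound the cells tolerate. No measurement here bears on why the result came out this way.

Going by these compounds, it remains open whether another group on that nitrogen, such as a methyl group, a longer chain or a chain ending in an amine or a carboxylic acid, would shift the number beyond that spread. Compound 1 and compound 2 carry substituted benzyl groups but have no number, so they cannot help settle this.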